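A few compounds are considered here, and "the series" means these few. Any claim that something is new, unique, unknown or untested is made for them only; others in the source may bear on it.

Of the compounds shown here, three have been measured in a functional assay on U-87MG ATCC cells (Homo sapiens) for cytotoxicity, read by MTT assay, with a stated time of 48 h; a lower number here means a stronger inhibitor, a higher number a weaker inhibitor. Compound 3 (`C/C(=N\NC(=S)Nc1ccccc1)c1ccccn1`) gives 1.4 nM and compound 2 (`C/C(=N\NC(=S)Nc1ccccc1Cl)c1ccccn1`) gives 2.6 nM, two values within the scatter of each other. Compound 1 (`CC(=NNC(=S)Nc1ccccc1[N+](=O)[O-])c1ccccn1`) gives 4.3 nM, a higher number than that of compound 3 by more than the scatter.

Compound 4 (`C/C(=N\NC(=S)Nc1ccccc1[N+](=O)[O-])c1ccccn1`) departs from compound 3 by one change, nitro in place of hydrogen on an aromatic carbon. Going by the values given here, one measured step bears on this exchange at the same kind of place, though with a different group: a 1.9-fold lower number from compound 2 to compound 3 (0.27 log units; within the scatter). It is small, and read in reverse it points only weakly towards a higher number when a group replaces hydrogen. Closer evidence comes from compound 1 at 4.3 nM, which carries the same nitro group on the same ring but leaves the geometry of its double bond undefined. What that geometry contributes has not been measured. A moderate step towards a higher number is therefore expected in this assay, a little beyond the scatter. The expected step is a 2.9-fold higher number from compound 3 to compound 4 (0.46 log units; beyond the scatter). The estimated value for compound 4 is 4 nM, with an expected range from 2 nM to 8 nM.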

Compound 4, half-maximal inhibitory concentration: 4.3 nM
The estimate for compound 4 lay 1.1-fold (0.03 log units) below the measured number; the range from low to high includes it.
By their numbers in this assay, from the lowest: compounds 3, 2, 1 and 4 (each within the scatter of the next, the first and the last beyond it).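

In this assay, nitro in place of hydrogen on an aromatic carbon, ortho to a large group, gives a 3.1-fold higher number from compound 3 to compound 4 (0.49 log units; beyond the scatter), so this position now shows a modest step that exceeds the scatter, which the chloro compound alone did not show. Nitro and chloro at this carbon cannot be told apart, as nitro in place of chloro gives a 1.7-fold higher number from compound 2 to compound 4 (0.22 log units; within the scatter), and with only these two groups no order between them can be read. The open question about the double bond is also settled for this pair, since defining it as E gives no change at the digits printed from compound 1 to compound 4 (within the scatter), and the only thing separating the two entries is this: the fact that one of compounds 1 and 4 is drawn with a defined configuration and the other without, at the place where they differ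

The compounds shown leave open how an amine or a carboxylic acid on the same aromatic carbon would compare with hydrogen, chloro and nitro. They also leave open whether nitro on another carbon of that ring would give a step of similar size, and how a double bond drawn Z would read in this assay.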